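The source may hold more compounds than are shown below. What is called first, only, known or untested is meant among the compounds shown, and "the series" means these compounds.

Measured compounds, with their values in a functional assay on HCT-15 cells (Homo sapiens) for cytotoxicity, read by CCK-8 assay; a higher number here means a weaker inhibitor, a lower number a stronger inhibitor:

- compound 1, `Oc1ccc(-c2cc(-c3cccs3)cc(-c3ccc(O)cc3)n2)cc1`, reaches only the limit of this assay, > 50000 nM
- compound 2, `Oc1ccc(-c2cc(-c3ccco3)cc(-c3ccc(O)cc3)n2)cc1`, gives 14000 nM
- compound 3, `Oc1ccc(-c2cc(-c3ccoc3)cc(-c3cccc(O)c3)n2)cc1`, gives 930 nM

Compound 3 holds the lowest of the two numbers; the next one, compound 2, sits at a far higher number. Among the measured compounds shown here, the one measured step, an at least 3.5-fold lower number from compound 1 to compound 2 (0.55 log units; beyond the scatter), concerns a change from a sulfur-containing five-membered ring to an oxygen-containing one, and the value of compound 1 is a limit, as the limit of > 50000 nM in this assay, at which 1 of the 3 values shown sits, records.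

Compound 4, `Oc1ccc(-c2cc(-c3ccoc3)cc(-c3ccc(O)cc3)n2)cc1`, has not been measured. It differs from compound 3 by 4-hydroxyphenyl in place of 3-hydroxyphenyl on an aromatic carbon. No measured step touches the position of the hydroxyl on this phenyl ring, so nothing among the shown results points in a direction for this change. The step is therefore expected to lie within the scatter, or at most be modest: a 1.6-fold higher number from compound 3 to compound 4 (0.21 log units; within the scatter). For compound 4 the estimated value in this assay is 1500 nM, expected to fall between 400 nM and 6000 nM.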

Compound 4, half-maximal inhibitory concentration: 1530 nM
For compound 4 the middle estimate is 1.0-fold (0.01 log units) below the measured one; low and high end bracket the measured number.
By their numbers in this assay, from the lowest: compounds 3 and 4 (each within the scatter of the next); then compound 2. At a limit, above all of these: compound 1.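

In this assay, 3-hydroxyphenyl and 4-hydroxyphenyl cannot be told apart at this position of the core when furan-3-yl is present: a 1.6-fold higher number from compound 3 to compound 4 (0.22 log units; within the scatter). Among the compounds shown here, the way the furan is attached, which the earlier compounds did not test, does count: furan-3-yl in place of furan-2-yl gives a 9.2-fold lower number from compound 2 to compound 4 (0.96 log units; beyond the scatter), a step beyond the scatter with the two 4-hydroxyphenyl groups held constant. Furan-3-yl in place of thiophen-2-yl gives an at least 32-fold lower number from compound 1 to compound 4 (1.51 log units; beyond the scatter), but this step has only a lower bound, as it starts from a limit: the limit of > 50000 nM in this assay, at which 1 of the 4 values shown sits.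

From the compounds shown here alone, whether thiophen-3-yl would match furan-3-yl remains open, so the role of the ring oxygen is unsettled. Also open, going by these compounds, is what a methoxy group or an amine would do in place of the hydroxyl on the phenyl ring.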